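Chloro for Fluoro on the Benzyl Group of Compound 2

The source may hold more compounds than are shown below. What is called first, only, known or untested is meant among the compounds shown, and "the series" means these compounds.

Going by the values given here, compound 2 `Cc1ccc(NC(=S)N/N=C2\C(=O)N(Cc3ccc(F)cc3)c3ccc(Br)cc32)cc1` gives 190000 nM in a functional assay on L1210 cells (Mus musculus), with a stated time of 48 h (on this read-out higher numbers stand for weaker inhibition and lower numbers for stronger inhibition), the higher of the two numbers measured so far. Among the compounds with values here, compound 1 `Cc1ccc(NC(=S)N/N=C2\C(=O)Nc3ccc(Br)cc32)cc1` gives 9600 nM in this assay, and the step of a 20-fold higher number from compound 1 to compound 2 (1.30 log units; beyond the scatter) is the only measured step. Compound 3 `Cc1ccc(NC(=S)N/N=C2\C(=O)N(Cc3ccc(Cl)cc3)c3ccc(Br)cc32)cc1` differs from compound 2 by chloro in place of fluoro on an aromatic carbon, sitting para to a large group. Within the data shown here, no measured pair shows a halogen swap, so nothing measured bears directly on this change; compound 3 is expected to stay near compound 2, with the step of no change at the digits printed from compound 2 to compound 3 (within the scatter) expected to remain within the scatter. For compound 3 the estimate is 190000 nM, ranging from 70000 nM to 500000 nM.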

Compound 3, half-maximal inhibitory concentration: >= 500000 nM
Compound 3: a limit, no number; the forecaster's own chance of this, stated with the estimate: 15%; middle value at least 2.6-fold (0.42 log units) from the limit.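

The para halogen on the benzyl group is not a silent position: 4-chlorobenzyl in place of 4-fluorobenzyl gives an at least 2.6-fold higher number from compound 2 to compound 3 (0.42 log units; beyond the scatter) in this assay. Set against the amide hydrogen, the 4-chlorobenzyl group gives an at least 52-fold higher number from compound 1 to compound 3 (1.71 log units; beyond the scatter), so this second substituent on that nitrogen also reads weaker than compound 1. Compound 3 stands at an assay limit, not a number: the limit of >= 500000 nM in this assay, at which 1 of the 3 values shown sits.

Still open, as far as these compounds go, is whether a methyl group on that nitrogen would read closer to compound 1. Also open, from the compounds shown here alone, is how an amine or a carboxylic acid at the same place on the benzyl ring would read.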